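Amino to Carboxy on a Shared Core

The compounds below may be only part of what the source reports. "The series", "measured", "known", "first", "only" and "open" are said of these compounds alone.

Of the compounds shown here, two have so far been measured in a functional assay (aorta) with Rattus norvegicus as the target; on this read-out higher numbers stand for weaker inhibition and lower numbers for stronger inhibition. Compound 1 `CC1(C)Oc2ccc(C#N)cc2[C@@H](/N=C(\NC#N)Nc2ccc(N)cc2)[C@@H]1O` gives 3500 nM and holds the lowest of the two numbers. Compound 2 `CCC(C)(C)/N=C(\NC#N)N[C@@H]1c2cc(C#N)ccc2OC(C)(C)[C@H]1O` gives 29800 nM, a value that lies beyond the scatter from compound 1 in the direction of weaker inhibition. Compound 3 `CC1(C)Oc2ccc(C#N)cc2[C@@H](/N=C(\NC#N)Nc2ccc(C(=O)O)cc2)[C@@H]1O` is the next member to be measured in this assay. It differs from compound 1 at a single place: carboxy in place of amino on an aromatic carbon. Among the compounds with values here, no measured pair in the set shares this change, so there is no step from which its size can be read directly. On the numbers available, only a modest step towards weaker inhibition is expected, a 2.0-fold higher number from compound 1 to compound 3 (0.30 log units; within the scatter). Compound 3 is therefore estimated at 7000 nM in this assay, with a range from 2000 nM to 25000 nM.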

Compound 3, half-maximal inhibitory concentration: > 100000 nM
Compound 3: a limit, no number; the forecaster's own chance of this, stated with the estimate: 10%; middle value at least 14-fold (1.15 log units) away from the limit.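

Compound 3 sits at a limit of the assay, not at a number: the limit of > 100000 nM in this assay, at which 1 of the 3 values shown sits. Even so, the step can be read as an at least 28-fold higher number from compound 1 to compound 3 (1.45 log units; beyond the scatter), which shows that carboxy in place of amino, on an aromatic carbon para to a large group, is a large change in this assay. Within the data shown here, no earlier compound gave a step at this place, so this is the first sign that the read-out depends strongly on the group held there, and the full size of the change stays hidden behind the limit.

Among these compounds, the single pair cannot tell whether the loss follows from the entering carboxylic acid or from the leaving amine. A plain hydrogen, a hydroxyl, a methyl ester or a primary amide on the same carbon would separate the two, and the compounds shown include none of these.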